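Swapping chloro for methoxy on compound 2

A few compounds are considered here, and "the series" means these few. Any claim that something is new, unique, unknown or untested is made for them only; others in the source may bear on it.

Of the compounds shown here, two have numbers so far. Compound 1 (`Cn1cc(C2CC(c3ccccc3)=NN2C(=O)c2ccncc2)c2ccccc21`) gives 990 nM in a functional assay on A549 cells (Homo sapiens) for inhibition, read by MTT assay, with a stated time of 48 h (on this read-out higher numbers stand for weaker inhibition of growth and lower numbers for stronger inhibition of growth), and compound 2 (`COc1ccc2c(c1)c(C1CC(c3ccc(Cl)cc3)=NN1C(=O)c1ccc(OC)nc1)cn2C`) gives 3390 nM on the same read-out. Compound 2 therefore holds the higher of the two numbers, meaning the weaker inhibition of growth, and its gap to compound 1 lies beyond the usual scatter. The two compounds differ in more than one place, so the data do not tie that gap to any single group.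

Compound 3 (`COc1ccc(C2=NN(C(=O)c3ccc(OC)nc3)C(c3cn(C)c4ccc(OC)cc34)C2)cc1`) departs from compound 2 in one place only, as methoxy in place of chloro on an aromatic carbon sets out: methoxy in place of chloro on an aromatic carbon, turning 4-chlorophenyl into 4-methoxyphenyl. For the measured compounds named here, no measured pair shows this exchange, so there is no direct precedent for it in this assay and no ground for expecting a large move. The expected change is a 1.4-fold lower number from compound 2 to compound 3 (0.13 log units; within the scatter) and it is estimated to stay within the scatter. Compound 3 is estimated at 2500 nM with a range of 1100 nM to 6000 nM as its expected result in this assay once measured.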

Compound 3, concentration for 50% growth inhibition: 450 nM
Estimate against measurement, compound 3: 5.6-fold (0.74 log units) above; measured number below the stated range.
By their numbers in this assay, from the lowest: compound 3; then compound 1; then compound 2.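

On the aromatic carbon para to a large group, 4-methoxyphenyl in place of 4-chlorophenyl gives a 7.5-fold lower number from compound 2 to compound 3 (0.88 log units; beyond the scatter) in this assay, a step beyond the scatter. For the compounds shown here, this is the first comparison here in which a change in one place can be tied to a move in the read-out, and it shows that this position on the shared core can alter inhibition of growth in these cells, with methoxy the better of the two groups tested there. Nothing measured here accounts for the size of this step or explains why methoxy gives the lower number.

The compounds shown give only these two groups at this position, so they do not tell whether the step belongs to methoxy in particular or would also appear with a hydroxyl group, an ethoxy group or an amine in the same place. They also leave open whether the same exchange would give a step of similar size on the core of compound 1, which differs from compound 2 in more than one place.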